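Swapping a Halogenated Ring in a Cytotoxicity Series

This account rests on a few compounds, and the source may have more. Where it says the series, first, only, none or still open, it means among the compounds named here.

Three compounds have so far been tested in a functional assay on PC-12 cells (Rattus norvegicus) for cytotoxicity, read by MTT assay, with stated times of 2 h and 24 h, tested at 10 uM; a higher number here means a stronger effect of the compound at the concentration tested, a lower number a weaker effect:

Compound 1, `Oc1cc(C(F)(F)F)ccc1-c1nc(-c2ccccc2O)n(-c2ccc(Br)cc2)n1`, gives 100%
Compound 2, `COc1cccc(-n2nc(-c3ccc(C(F)(F)F)cc3O)nc2-c2ccccc2O)c1`, gives 106%
Compound 3, `Oc1cc(C(F)(F)F)ccc1-c1nc(-c2ccccc2O)n(-c2ccc(F)cc2F)n1`, gives 97.9%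

Compound 3 has the lowest of the three numbers, yet its distances to compound 1 and compound 2 both lie within the usual scatter, so the three cannot be ranked. Compound 4, `Oc1cc(C(F)(F)F)ccc1-c1nc(-c2ccccc2O)n(-c2ccc(Cl)cc2Cl)n1`, is not yet measured; it differs from compound 3 in one place: 2,4-dichlorophenyl in place of 2,4-difluorophenyl on an aromatic nitrogen. All three measured steps swap the ring on the same aromatic nitrogen: a number 6 percentage points higher from compound 1 to compound 2 (within the scatter), a number 2.1 percentage points lower from compound 1 to compound 3 (within the scatter) and a number 8.1 percentage points lower from compound 2 to compound 3 (within the scatter). None leaves the scatter, so no step beyond the scatter is expected in this assay here either; the expected a number 1.1 percentage points higher from compound 3 to compound 4 (within the scatter) is small. For compound 4 the estimate is 99%, with a range from 87% to 111%.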

Compound 4, a percentage reported as activity, at one concentration (the size of the read-out at that concentration, not a potency): 95.2%
Beside the measured number, compound 4's estimate is 3.8 percentage points above it; low and high end bracket the measured number.
By their numbers in this assay, from the lowest: compounds 4, 3, 1 and 2 (each within the scatter of the next, the first and the last beyond it).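

In this assay, a change on this aromatic nitrogen now gives a step beyond the scatter, though only a modest one: 2,4-dichlorophenyl in place of 3-methoxyphenyl gives a number 10.8 percentage points lower from compound 2 to compound 4 (beyond the scatter) here. The two halogen-for-halogen swaps do not separate the compounds, with 2,4-dichlorophenyl in place of 2,4-difluorophenyl giving a number 2.7 percentage points lower from compound 3 to compound 4 (within the scatter) and in place of 4-bromophenyl giving a number 4.8 percentage points lower from compound 1 to compound 4 (within the scatter) in this series. Within the data shown here, nothing available explains the one larger step. Still open, from the compounds shown here alone, is whether a phenyl ring bearing an amine or a carboxylic acid, or a longer alkyl chain in place of the ring, would move the number further at this nitrogen.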